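A few compounds are considered here, and "the series" means these few. Any claim that something is new, unique, unknown or untested is made for them only; others in the source may bear on it.

In a functional assay on PC-3 cells (Homo sapiens) for cytotoxicity, read by MTT assay, with a stated time of 72 h (on this read-out higher numbers stand for weaker inhibition and lower numbers for stronger inhibition), compound 1 `CC(=O)c1ccc(/N=C2\C=C(OCc3cn(S(=O)(=O)c4ccc(C)cc4)nn3)C(=O)c3ccccc32)cc1` gives 3910 nM and compound 2 `Cc1ccc(/N=C2\C=C(OCc3cn(S(=O)(=O)c4ccc(C)cc4)nn3)C(=O)c3ccccc32)cc1` gives 2650 nM, so the two stand within the scatter of each other and show no order. Compound 3 `Cc1ccc(S(=O)(=O)n2cc(COC3=C/C(=N\c4ccc(F)cc4)c4ccccc4C3=O)nn2)cc1` has fluoro in place of acetyl on an aromatic carbon, para to a large group: fluoro in place of acetyl on an aromatic carbon. Within the data shown here, the one measured step that bears on this change, a 1.5-fold lower number from compound 1 to compound 2 (0.17 log units; within the scatter), also removes the acetyl. No step beyond the scatter is therefore expected in this assay, in either direction. The expected step is a 1.3-fold lower number from compound 1 to compound 3 (0.12 log units; within the scatter). The estimate for compound 3 is 3000 nM, with an expected range of 1300 nM to 7000 nM.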

Compound 3, half-maximal inhibitory concentration: 2030 nM
Compound 3: the middle estimate sits 1.5-fold (0.17 log units) above what was measured; measured number inside the range.
By their numbers in this assay, from the lowest: compounds 3, 2 and 1 (each within the scatter of the next).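

In this assay, fluoro at this place, para to a large group, stays within the scatter of both acetyl (a 1.9-fold lower number from compound 1 to compound 3 (0.28 log units; within the scatter)) and methyl (a 1.3-fold lower number from compound 2 to compound 3 (0.12 log units; within the scatter)). Across these three compounds, going from acetyl to a single fluorine atom therefore gives no readable order, even though acetyl has three heavy atoms and a hydrogen-bond acceptor. No measurement is available to explain this lack of separation. As far as these compounds go, whether an amine, a carboxylic acid or a longer chain at this place would give a step beyond the scatter remains open.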